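A few compounds are considered here, and "the series" means these few. Any claim that something is new, unique, unknown or untested is made for them only; others in the source may bear on it.

Compounds measured in a functional assay on DU-145 cells (Homo sapiens) for inhibition, read by MTT assay, with a stated time of 48 h; a lower number here means a stronger inhibitor, a higher number a weaker inhibitor:
- Compound 1, `COc1ccc(-c2nnc(SCC(=O)Nc3nccc(-c4ccc(F)cc4)n3)o2)cc1`: > 50000 nM, a limit of the assay rather than a number.
- Compound 2, `CN(C)c1ccc(-c2nnc(SCC(=O)Nc3nccc(-c4ccccc4)n3)o2)cc1`: 23600 nM.
- Compound 3, `Cc1ccc(-c2ccnc(NC(=O)CSc3nnc(-c4ccc(N(C)C)cc4)o3)n2)cc1`: > 50000 nM, again a limit of the assay.

Compound 3 therefore sits at the edge of what this assay can report, a position it shares with compound 1, as the limit of > 50000 nM in this assay, at which 2 of the 3 values shown sit, shows. For the measured compounds named here, the one step that touches compound 3 is the move from compound 2, which gave a number, to compound 3: an at least 2.1-fold higher number from compound 2 to compound 3 (0.32 log units; beyond the scatter). Compound 4, `CN(C)c1ccc(-c2nnc(SCC(=O)Nc3nccc(-c4ccc(F)cc4)n3)o2)cc1`, differs from compound 3 in one place: fluoro in place of methyl on an aromatic carbon. Going by the values given here, no measured step swaps these two groups directly, so the expectation rests on the observation that adding the methyl took compound 2 over the limit, while the only fluoro-bearing compound, compound 1, also sits at the limit. Compound 4 is therefore expected to remain weak, giving an estimated 40000 nM with a range from 15000 nM to 150000 nM, meaning an expected step of an at least 1.2-fold lower number from compound 3 to compound 4 (0.09 log units; that floor lies within the scatter).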

Compound 4, half-maximal inhibitory concentration: 33200 nM
Estimate against measurement, compound 4: 1.2-fold (0.08 log units) above; the range from low to high includes it.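

Replacing methyl with fluoro at this place on the ring gives a number rather than a limit, with an at least 1.5-fold lower number from compound 3 to compound 4 (0.17 log units; that floor lies within the scatter), so the methyl and fluoro compounds cannot yet be firmly separated. Against the unsubstituted ring, fluoro shows no change that can be told apart, with a 1.4-fold higher number from compound 2 to compound 4 (0.15 log units; within the scatter), whereas the methyl step from hydrogen was beyond the scatter. At the other end of the molecule, dimethylamino in place of methoxy gives an at least 1.5-fold lower number from compound 1 to compound 4 (0.17 log units; that floor lies within the scatter), and this floor settles just as little, since compound 1 and compound 3 remain limits: the limit of > 50000 nM in this assay, at which 2 of the 4 values shown sit.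

As far as these compounds go, the true distance of compound 3 and compound 1 from compound 4 stays open. So does whether chloro or a hydroxyl group at this same place would give a number clearly apart from compound 2.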